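Swapping the amide substituent in a cytotoxicity series

The source may report more compounds than this note shows. Statements on the series, on what has been measured and on what is new or still open speak of the compounds shown alone.

This series shares one core, seen in compound 1 `O=C(CSc1nnc(-c2ccncc2)s1)Nc1ccc(Cl)cc1` and compound 2 `O=C(CSc1nnc(-c2ccncc2)s1)Nc1c(Cl)cccc1Cl`, which differ only in the aryl group on the amide nitrogen. In an ADME assay on BHK-21 cells (Mesocricetus auratus) for cytotoxicity, with a stated time of 3 days (a lower number here means that less compound is tolerated, a higher number that more compound is tolerated), compound 1 reaches the limit of the assay, > 50000 nM, which is a limit rather than a measured number. That is where the evidence sits: the limit of > 50000 nM in this assay, at which 1 of the 2 values shown sits. For compound 2 the outcome in this assay is "not determined" (no result reported), so no number places it anywhere on the scale. Compound 3 `O=C(CSc1nnc(-c2ccncc2)s1)NCc1ccccc1` carries benzyl in place of 2,6-dichlorophenyl on an amide-type nitrogen. Since compound 2 has no result, the step from compound 2 to compound 3 in this assay cannot be measured; the expectation is a change of no more than the usual scatter, in neither direction, resting on compound 1 at > 50000 nM. The half-maximal cytotoxic concentration of compound 3 is therefore estimated at 60000 nM, within 20000 nM to 200000 nM.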

Compound 3, half-maximal cytotoxic concentration: 11300 nM
For compound 3 the middle estimate is 5.3-fold (0.73 log units) above the measured one; measured number outside the range, below it.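

Within the data shown here, compound 3 gives the first real number on the scale, 11300 nM, so the group on the amide-type nitrogen can be tied to a measurable level of cytotoxicity. In this assay, placing benzyl in place of 4-chlorophenyl gives an at least 4.4-fold lower number from compound 1 to compound 3 (0.64 log units; beyond the scatter), which shows that this one change can lower the concentration the cells tolerate. Compound 1 remains a limit and not a number, so the comparison rests on that limit: the limit of > 50000 nM in this assay, at which 1 of the 3 values shown sits.

The step from the 2,6-dichlorophenyl compound cannot be read, which leaves that group's place in this assay unknown. From the compounds shown here alone, it also stays open whether the step follows the loss of chlorine or the shift from an aryl to a benzyl group, a question that a plain phenyl or a 4-chlorobenzyl group on the same nitrogen could help to separate.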